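Removing the aromatic group from sulfur in compound 3

The compounds below may be only part of what the source reports. "The series", "measured", "known", "first", "only" and "open" are said of these compounds alone.

Among the compounds with values here, in a functional assay on MGC-803 cells (Homo sapiens) for inhibition, read by CCK-8 assay, with a stated time of 48 h (a lower number here means a stronger inhibitor, a higher number a weaker inhibitor), compound 1 `COc1ccc(CN(C(=O)CSc2nc3ccccc3o2)c2cc(OC)c(OC)c(OC)c2)cc1` gives 450 nM and stands lowest of the two numbers so far, while compound 2 `CCN1CCN(C(=S)SCC(=O)N(Cc2ccc(OC)cc2)c2cc(OC)c(OC)c(OC)c2)CC1` gives 9890 nM under the same conditions. Within the data shown here, compound 3 `COc1ccc(CN(C(=O)CSC(=S)N2CCOCC2)c2cc(OC)c(OC)c(OC)c2)cc1` differs from compound 1 through a group of 8 heavy atoms (5 carbon, 1 nitrogen, 1 oxygen, 1 sulfur; one six-membered non-aromatic ring with 2 hetero atoms) in place of a group of 9 heavy atoms (7 carbon, 1 nitrogen, 1 oxygen; one five-membered aromatic ring with 2 hetero atoms, one six-membered aromatic ring of carbon only), on a sulfur as its single change, so the 1,3-benzoxazol-2-yl group is lost. Among the measured compounds shown here, the only guide is a 22-fold higher number from compound 1 to compound 2 (1.34 log units; beyond the scatter) where that same group also leaves, so a large upward step is expected here too. The expected change is an 11-fold higher number from compound 1 to compound 3 (1.05 log units; beyond the scatter) on this single precedent. Compound 3 is therefore estimated at 5000 nM with a likely range from 1500 nM to 15000 nM in this measurement.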

Compound 3, half-maximal inhibitory concentration: 2370 nM
Compound 3: middle estimate off by 2.1-fold (0.32 log units), on the high side; the measured number falls inside the stated range.
By their numbers in this assay, from the lowest: compound 1; then compound 3; then compound 2.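

In this assay, swapping the 1,3-benzoxazol-2-yl group on the sulfur for morpholin-4-yl on a thiocarbonyl carbon gives a smaller loss than the earlier swap (a 5.3-fold higher number from compound 1 to compound 3 (0.72 log units; beyond the scatter)). The group on that thiocarbonyl carbon therefore matters in its own right: morpholin-4-yl in place of 4-ethylpiperazin-1-yl gives (a 4.2-fold lower number from compound 2 to compound 3 (0.62 log units; beyond the scatter)), and compound 1 remains the lowest of the three. Nothing available explains these steps. Still open, on these data alone, is how a 1,3-benzothiazol-2-yl group on the sulfur, or a piperidin-1-yl group on the thiocarbonyl carbon, would compare.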